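The compounds below may be only part of what the source reports. "The series", "measured", "known", "first", "only" and "open" are said of these compounds alone.

Compound 1 `Cc1cc(C)cc(/C=C(/SCc2ccc(F)cc2)C(=O)c2ccc(Br)cc2)c1` was tested in a functional assay on DU-145 cells (Homo sapiens) for inhibition, read by trypan blue exclusion, with a stated time of 96 h (a higher number here means a weaker inhibitor of growth, a lower number a stronger inhibitor of growth), where compound 1 gives 10000 nM. Two related compounds were measured alongside it. Compound 2 `Cc1ccc(CS(=O)(=O)/C(=C/c2ccc(S(C)(=O)=O)cc2)C(=O)c2ccc(Br)cc2)cc1` gives 10000 nM in this assay, and compound 3 `Cc1ccc(CS/C(=C/c2cc(C)ccc2C)C(=O)c2ccc(Cl)cc2)cc1` gives 10000 nM in this assay. On these numbers compound 1 stands level with compound 2 and with compound 3; none of the three is separated from another by more than the usual scatter of the measurement, so no ordering among them can be read off.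

Compound 4 `Cc1ccc(C)c(/C=C(/SCc2ccc(F)cc2)C(=O)c2ccc(Br)cc2)c1` has not yet been measured in this assay. It has the same atoms as compound 1, joined differently: 2,5-dimethylphenyl in place of 3,5-dimethylphenyl on a double-bonded chain carbon bound to a double-bonded chain carbon. The rest of the shared core is unchanged. Among the measured compounds shown here, no measured pair in this set differs in one place, so there is no comparable step to lean on. Because compound 1 gives 10000 nM and its neighbours show no spread around it, the step of no change at the digits printed from compound 1 to compound 4 (within the scatter) is expected to be none beyond the scatter. Compound 4 is therefore estimated at 10000 nM, with a range from 4000 nM to 25000 nM.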

Compound 4, concentration for 50% growth inhibition: 1000 nM
For compound 4 the middle estimate is 10-fold (1.00 log units) above the measured one; measured number below the stated range.
By their numbers in this assay, from the lowest: compound 4; then compounds 1, 2 and 3 (each within the scatter of the next).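

In this assay, putting 2,5-dimethylphenyl in place of 3,5-dimethylphenyl gives a 10-fold lower number from compound 1 to compound 4 (1.00 log units; beyond the scatter), even though the two compounds have the same atoms. The earlier compounds shown here all stood level and so gave no sign that any part of the structure mattered, whereas this pair shows that the number responds to where the two methyl groups sit on this ring alone. This holds for this one pair only, and nothing measured here explains the step.

The compounds shown leave open whether a single methyl group on this ring would keep the lower number, or whether a methoxy group or an amine could take the place of either methyl group. They also leave open whether the same swap would give a similar step with other groups on the sulfur or on the ketone side of the molecule.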